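The source may report more compounds than this note shows. Statements on the series, on what has been measured and on what is new or still open speak of the compounds shown alone.

Measured so far:
- Compound 1 `C/C(=N\NC(N)=O)c1ccc2c(c1)nc(-c1ccc(C(F)(F)F)cc1)n2C1CCCCC1`: "not determined" (no result reported)
- Compound 2 `C/C(=N\NC(N)=S)c1ccc2c(c1)nc(-c1ccccc1)n2C1CCCCC1`: 20000 nM

The measure here is an ADME assay on MT4 cells (Homo sapiens) for cytotoxicity, read by MTT assay, with a stated time of 96 h; a lower number here means that less compound is tolerated, a higher number that more compound is tolerated. For the measured compounds named here, compound 1 has no result in this assay, so compound 2, at 20000 nM, holds the only number available. With nothing to compare it against, it cannot yet be called high or low within this small set.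

The next compound is compound 3 `C/C(=N\NC(N)=S)c1ccc2c(c1)nc(-c1ccc(C(F)(F)F)cc1)n2C1CCCCC1`, which keeps the shared core of compound 2 and changes one place: trifluoromethyl in place of hydrogen on an aromatic carbon. In other words, a phenyl becomes a 4-(trifluoromethyl)phenyl, with trifluoromethyl in place of hydrogen on an aromatic carbon.

Going by the values given here, no measured pair shows what this change does in this assay, so any forecast is uncertain and rests on compound 2 at 20000 nM as its starting point. A small move towards a lower number is expected, possibly no larger than the usual scatter of repeat measurements. The expected change is a 1.4-fold lower number from compound 2 to compound 3 (0.15 log units; within the scatter). For compound 3 the estimated value is 14000 nM, with an expected range of 5000 nM to 40000 nM.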

Compound 3, half-maximal cytotoxic concentration: 30000 nM
For compound 3 the middle estimate is 2.1-fold (0.33 log units) below the measured one; measured number inside the range.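

In this assay, trifluoromethyl in place of hydrogen gives a 1.5-fold higher number from compound 2 to compound 3 (0.18 log units; within the scatter) at this position, an aromatic carbon of a six-membered aromatic ring of carbon only, para to a large group. For the compounds shown here, this pair gives the first direct reading of the change: swapping a hydrogen atom for a group of 4 heavy atoms leaves the tolerated concentration indistinguishable from that of the unsubstituted phenyl, given the normal variation between repeat measurements. Nothing available offers an explanation for this outcome, so it stands as an observation only.

A single pair cannot show how the position responds to other groups, such as an amine, a carboxylic acid or a longer chain, or whether a different spot on the same ring would give a similar reading. From the compounds shown here alone, compound 1 differs from compound 3 in one place, a carbonyl where compound 3 has a thiocarbonyl, but compound 1 has no number, so that comparison cannot be read and the effect of this swap remains open.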